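Hydroxyalkyl chain series: cytotoxicity notes toward compound 4

The source may report more compounds than this note shows. Statements on the series, on what has been measured and on what is new or still open speak of the compounds shown alone.

Three analogues of a shared core have been run in a functional assay on MT4 cells (Homo sapiens) for cytotoxicity; on this read-out lower numbers stand for higher toxicity in this test and higher numbers for lower toxicity in this test. Compound 1 `Cc1cn(C2CC(N=[N+]=[N-])C(COC(=O)OCCO)O2)c(=O)[nH]c1=O` carries the shortest hydroxyalkyl chain; in this assay compound 1 reports only a limit, > 50000 nM. Compound 2 `Cc1cn(C2CC(N=[N+]=[N-])C(COC(=O)OCCCCCCCCO)O2)c(=O)[nH]c1=O` carries the longest chain; in this assay compound 2 likewise reaches only a limit, > 50000 nM. Compound 3 `Cc1cn(C2CC(N=[N+]=[N-])C(COC(=O)OCCCCCO)O2)c(=O)[nH]c1=O` carries a chain shorter than that of compound 2; in this assay compound 3 also gives only a limit, > 50000 nM. The steps among these three, a step that the two limits leave unreadable from compound 1 to compound 2, a step that the two limits leave unreadable from compound 1 to compound 3 and a step that the two limits leave unreadable from compound 2 to compound 3, set no size, since every value rests on (the limit of > 50000 nM in this assay, at which 3 of the 3 values shown sit).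

Compound 4 `Cc1cn(C2CC(N=[N+]=[N-])C(COC(=O)OCCCC(=O)OC(C)(C)C)O2)c(=O)[nH]c1=O` differs from compound 3 by tert-butoxycarbonyl in place of 2-hydroxyethyl on a saturated chain carbon, three bonds along the chain from an oxygen next to a carbonyl group. Among the compounds with values here, no measured step bears directly on exchanging a hydroxyl-terminated chain for a tert-butoxycarbonyl group, and none of the measured steps has a readable size to lean on. Within the data shown here, the only guidance is that compound 1, compound 2 and compound 3 all sit at the limit of > 50000 nM in this assay, at which 3 of the 3 values shown sit. The step that the limit leaves unreadable from compound 3 to compound 4 is thus expected to show no change beyond the scatter, and compound 4 is expected to be reported again as a limit. The estimate for compound 4 in this assay is 60000 nM, within a range from 20000 nM to 200000 nM.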

Compound 4, half-maximal cytotoxic concentration: > 50000 nM
Compound 4 ended at the assay's limit; the forecaster's own chance of this, stated with the estimate: 80%; the middle value does not contradict the limit.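

In this assay, within the data shown here, compound 4 gives > 50000 nM, which is a limit, so no step linking it to compound 1, compound 2 or compound 3 can be read: the limit of > 50000 nM in this assay, at which 4 of the 4 values shown sit. The compounds shown leave open what cytotoxic concentration any of these chains on the shared core would give as an actual number.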